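The source may report more compounds than this note shows. Statements on the series, on what has been measured and on what is new or still open speak of the compounds shown alone.

Measured so far:
Compound 1, `CCCCCCCCNC(=O)[C@@H](NC(=O)c1nccc2ccccc12)[C@@H](C)O`: in a functional assay on A-431 cells (Homo sapiens) for cytotoxicity, read by MTT assay, with a stated time of 48 h (a higher number here means a weaker inhibitor, a lower number a stronger inhibitor), compound 1 gives 26900 nM.
Compound 2, `CCCCCCCCCCCCCCNC(=O)[C@@H](NC(=O)c1cccs1)[C@@H](C)O`: compound 2 gives 26500 nM.
Compound 3, `CCCCCCCCCCCCCCNC(=O)[C@@H](NC(=O)c1cc2ccccc2o1)[C@@H](C)O`: compound 3 gives 20100 nM.

Compound 3 has the lowest of the three numbers, but its distances to compound 2 and to compound 1 both lie within the usual scatter, so the three compounds cannot be placed in an order on these data. Compound 4, `CCCCCCCCCCCCCCNC(=O)[C@@H](NC(=O)c1nccc2ccccc12)[C@@H](C)O`, has not yet been measured in this assay. It differs from compound 3 in one place: isoquinolin-1-yl in place of 1-benzofuran-2-yl on a carbonyl carbon. Within the data shown here, only one measured step swaps this aromatic group: a 1.3-fold lower number from compound 2 to compound 3 (0.12 log units; within the scatter), a change too small to count. Compound 1 carries the same isoquinolin-1-yl group as compound 4 on a shorter chain, and its number sits close to that of compound 3. Taken together, nothing here points to a real shift, so the step of a 1.2-fold higher number from compound 3 to compound 4 (0.08 log units; within the scatter) is expected to stay within the scatter. Compound 4 is therefore estimated at 24000 nM, with a range from 12000 nM to 48000 nM.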

Compound 4, half-maximal inhibitory concentration: 23000 nM
Compound 4: the middle estimate sits 1.0-fold (0.02 log units) above what was measured; the range from low to high includes it.
By their numbers in this assay, from the lowest: compounds 3, 4, 2 and 1 (each within the scatter of the next).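

In this assay, the step of a 1.1-fold higher number from compound 3 to compound 4 (0.06 log units; within the scatter) and the step of a 1.2-fold lower number from compound 2 to compound 4 (0.06 log units; within the scatter) add a third aromatic group at this position, and isoquinolin-1-yl, 1-benzofuran-2-yl and thiophen-2-yl on the carbonyl carbon cannot be told apart. Among these compounds, compound 4 also gives the first comparison of chain length with the aromatic group held fixed: hexyl in place of hydrogen on a saturated chain carbon, eight bonds along the chain from an amide-type nitrogen, gives a 1.2-fold lower number from compound 1 to compound 4 (0.07 log units; within the scatter), so this change has no readable effect either.

The compounds shown leave open whether an amine or a carboxylic acid in place of the aromatic group, or a chain shorter than that of compound 1, would move the number beyond the scatter. No measurement offered here accounts for how close these numbers lie.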